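Removing a methoxy group on the way to compound 4

The source may hold more compounds than are shown below. What is called first, only, known or untested is meant among the compounds shown, and "the series" means these compounds.

Measured so far:
compound 1, `Cc1nc(NC(=O)NCc2ccccc2)c2nn(-c3ccccc3)cc2n1`, 26%
compound 2, `Cc1nc(NC(=O)c2ccccc2)c2nn(-c3ccccc3)cc2n1`, 30%
compound 3, `COc1ccc(-n2cc3nc(C)nc(NC(=O)Nc4ccccc4)c3n2)cc1`, 5%

In an assay on CHO cells for displacement of a labelled ligand from adenosine receptor A1 (Homo sapiens), read by scintillation counting, with a stated time of 120 min, tested at 1 uM (a higher number here means more inhibition at the concentration tested (going by the name of the read-out), a lower number less inhibition), compound 3 gives the lowest of the three numbers, standing beyond the scatter below both compound 1 and compound 2. Compound 4, `Cc1nc(NC(=O)Nc2ccccc2)c2nn(-c3ccccc3)cc2n1`, has not been measured yet; it differs from compound 3 by hydrogen in place of methoxy on an aromatic carbon. Among the measured compounds shown here, no measured pair shows this change on its own. For the measured compounds named here, the only one-step pair, a number 4 percentage points higher from compound 1 to compound 2 (within the scatter), concerns a change elsewhere in the molecule and says little about it. Compound 4 does carry the same plain phenyl as compound 1 at 26% and compound 2 at 30%, so a rise above compound 3 is expected, though with wide uncertainty. Compound 4 is therefore estimated at 20%, between 0% and 45%. The expected step is a number 15 percentage points higher from compound 3 to compound 4 (beyond the scatter).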

Compound 4, a percentage reported as inhibition, at one concentration (the size of the read-out at that concentration, not a potency): 1%
Compound 4: middle estimate off by 19 percentage points, on the high side; the range from low to high includes it.
By their numbers in this assay, from the lowest: compounds 4 and 3 (each within the scatter of the next); then compounds 1 and 2 (each within the scatter of the next).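

Replacing the methoxy group with hydrogen gives a number 4 percentage points lower from compound 3 to compound 4 (within the scatter) in this assay, so going from 4-methoxyphenyl to phenyl at this position does not visibly move the reading. The low reading instead appears with changes on the carbonyl side: anilino in place of phenyl on the carbonyl carbon gives a number 29 percentage points lower from compound 2 to compound 4 (beyond the scatter), and phenyl in place of benzyl on the amide-type nitrogen gives a number 25 percentage points lower from compound 1 to compound 4 (beyond the scatter). Nothing measured here explains these differences.

As far as these compounds go, whether an amine or a chlorine in place of the methoxy would change the reading remains open. So does the effect of a phenylethyl group on the amide-type nitrogen.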